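The compounds below may be only part of what the source reports. "The series", "measured", "known", "first", "only" and "open" are said of these compounds alone.

Compound 1, `CC(C)Nc1nc(N)nc2c1ncn2/C=C1/CC1(CO)CO`, is tested in an ADME assay on Akata cells (Homo sapiens) for cytotoxicity, with a stated time of 7 days; a higher number here means that more compound is tolerated, a lower number that less compound is tolerated. There compound 1 gives only a limit, > 24000 nM. Compound 2, `Nc1nc(N2CCCC2)c2ncn(/C=C3/CC3(CO)CO)c2n1`, likewise reaches only a limit in this assay, > 24000 nM. Compound 3, `CC(C)Sc1nc(N)nc2c1ncn2/C=C1/CC1(CO)CO`, also gives a limit in this assay, > 20000 nM. The steps between these three compounds are a step that the two limits leave unreadable from compound 1 to compound 2, a step that the two limits leave unreadable from compound 1 to compound 3 and a step that the two limits leave unreadable from compound 2 to compound 3; every value sits either at the limit of > 20000 nM in this assay, at which 1 of the 3 values shown sits, or at the limit of > 24000 nM in this assay, at which 2 of the 3 values shown sit. Compound 4, `CCCCCCOc1nc(N)nc2c1ncn2/C=C1/CC1(CO)CO`, differs from compound 1 by hexyloxy in place of isopropylamino on an aromatic carbon. Within the data shown here, no measured step bears readably on this change, and no step beyond the scatter is expected from it. Compound 4 is expected to give 24000 nM, within 12000 nM to 60000 nM. The estimated step of a number no higher from compound 1 to compound 4 (the limit leaves the size open) is expected to be small.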

Compound 4, half-maximal cytotoxic concentration: > 20000 nM
Compound 4: a limit, no number (the forecaster's own chance of this, stated with the estimate: 70%); the middle value does not contradict the limit.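

No step can be read between compound 4 and compound 1, compound 2 or compound 3 in this assay, where all four compounds give only limits. The compounds shown leave open whether exchanging these groups changes the half-maximal cytotoxic concentration at all.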